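The compounds below may be only part of what the source reports. "The series", "measured", "known", "first", "only" and "open" are said of these compounds alone.

Measured compounds:
compound 1, `Nc1nc(O)c2c(n1)n(C1OC(CO)[C@@H](O)[C@H]1O)c(=O)n2Cc1ccc(Cl)c(Cl)c1`: 0%
compound 2, `C=CCn1c(=O)n(CCCC)c2nc(N)nc(O)c21`: 36%

In a functional assay on the whole organism with Mus musculus as the target (a lower number here means a smaller maximal response, a higher number a larger maximal response), compound 1 gives 0%, the lowest of the two numbers available. Compound 2 gives 36% in this assay, a gap that lies beyond the usual scatter of such measurements; since the two compounds differ in more than one place, their values show only that one of them reaches a sizeable response and the other none at all. Compound 3, `CCCCn1c(=O)n(C2OC(CO)[C@@H](O)[C@H]2O)c2nc(N)nc(O)c21`, has not yet been measured. It differs from compound 1 in a single place: propyl in place of 3,4-dichlorophenyl on a saturated chain carbon bound to an aromatic nitrogen. Among the measured compounds shown here, no measured pair differs in exactly this way, so the size of the step is open. Compound 2 also carries a butyl on the shared core and gives 36%, which leaves room for a response above that of compound 1. Compound 3 is expected to move by a number 15 percentage points higher from compound 1 to compound 3 (beyond the scatter) in this assay, a step that may or may not exceed the scatter. The estimate for compound 3 is 15%, with a range from 0% to 40%.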

Compound 3, largest response reached (reported as maximal response), in percent of the reference or control that the assay uses: 70%
Beside the measured number, compound 3's estimate is 55 percentage points below it; measured number outside the range, above it.
By their numbers in this assay, from the lowest: compound 1; then compound 2; then compound 3.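

Replacing 3,4-dichlorobenzyl with butyl on the shared core moves the response in this assay by a number 70 percentage points higher from compound 1 to compound 3 (beyond the scatter), so a single change at this place, on a saturated chain carbon bound to an aromatic nitrogen, is enough to separate a compound with no response from one with a large response. The earlier compounds shown here differed in more than one place and could tie no response to one group, whereas this pair holds everything else constant and places the whole difference at this position. The change removes the six-membered aromatic ring of carbon only and both chlorine atoms and brings in an open chain, and nothing measured alongside these values explains the size of the step.

The compounds shown leave open whether the step follows from losing the two chlorine atoms or from losing the ring, a question that an unsubstituted benzyl at this position would address. They also leave open how much further the chain can vary, for example a hexyl chain or a butyl chain ending in an amine or a carboxylic acid.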